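Pyrrolidine to piperidine swap on the propoxy chain

The source may report more compounds than this note shows. Statements on the series, on what has been measured and on what is new or still open speak of the compounds shown alone.

Compound 1 `COc1cc2c(Oc3ccc(NC(=O)c4nn(-c5cccc(F)c5)c(=O)cc4C)cc3F)ccnc2cc1OCCCN1CCCC1` is the reference of this short series; in a functional assay on U-87MG ATCC cells (Homo sapiens) for inhibition, read by MTT assay, with a stated time of 72 h (a lower number here means a stronger inhibitor, a higher number a weaker inhibitor), compound 1 gives 1700 nM. Compound 2 `COc1cc2c(Oc3ccc(NC(=O)c4nn(-c5cccc(F)c5)c(=O)cc4C)cc3F)ccnc2cc1OCCCN1CCCCC1` carries the change piperidin-1-yl in place of pyrrolidin-1-yl on a saturated chain carbon, three bonds along the chain from an oxygen on an aromatic ring and in this assay compound 2 gives 1500 nM, so the step of a 1.1-fold lower number from compound 1 to compound 2 (0.05 log units; within the scatter) does not separate the two compounds. Compound 3 `COc1cc2c(Oc3ccc(NC(=O)c4nn(-c5ccc(Cl)cc5)c(=O)cc4C)cc3F)ccnc2cc1OCCCN1CCCC1` differs from compound 1 in its core by 4-chlorophenyl in place of 3-fluorophenyl on an aromatic nitrogen; in this assay compound 3 gives 1430 nM, and the step of a 1.2-fold lower number from compound 1 to compound 3 (0.08 log units; within the scatter) again stays inside the scatter. All three measured numbers lie within the scatter of one another, so no order among them can be read.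

Compound 4 `COc1cc2c(Oc3ccc(NC(=O)c4nn(-c5ccc(Cl)cc5)c(=O)cc4C)cc3F)ccnc2cc1OCCCN1CCCCC1` has not been measured in this assay. It is obtained from compound 3 by piperidin-1-yl in place of pyrrolidin-1-yl on a saturated chain carbon, three bonds along the chain from an oxygen on an aromatic ring, which is the same change as that from compound 1 to compound 2, made on the core of compound 3 rather than on the core of compound 1. Because a 1.1-fold lower number from compound 1 to compound 2 (0.05 log units; within the scatter) is within the scatter, the same change on the other core is expected to be of about the same size, and the step of a 1.1-fold lower number from compound 3 to compound 4 (0.04 log units; within the scatter) is estimated accordingly. Compound 4 is therefore expected to give 1300 nM in this assay, with a range from 700 nM to 2500 nM that reflects the repeat scatter of the assay and the small number of compounds on which this expectation rests.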

Compound 4, half-maximal inhibitory concentration: 1400 nM
Compound 4: the middle estimate sits 1.1-fold (0.03 log units) below what was measured; measured number inside the range.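

In this assay, piperidin-1-yl in place of pyrrolidin-1-yl on the second core gives a 1.0-fold lower number from compound 3 to compound 4 (0.01 log units; within the scatter), and 4-chlorophenyl in place of 3-fluorophenyl with piperidin-1-yl on the chain gives a 1.1-fold lower number from compound 2 to compound 4 (0.03 log units; within the scatter). Set beside the earlier step, the amine change reads the same on both cores: the same change on two cores in this assay, a 1.1-fold lower number (0.05 log units; within the scatter) from compound 1 to compound 2 and a 1.0-fold lower number (0.01 log units; within the scatter) from compound 3 to compound 4, 1.1-fold (0.05 log units) apart, within the scatter of two such steps The aryl change also reads the same on both cores, but every step here lies within the scatter, so the series shows only that two changes with no readable effect on one core also have no readable effect on the other, and does not show that a change with a real effect would carry over at the same size: the same change on two cores in this assay, a 1.2-fold lower number (0.08 log units; within the scatter) from compound 1 to compound 3 and a 1.1-fold lower number (0.03 log units; within the scatter) from compound 2 to compound 4, 1.1-fold (0.05 log units) apart, within the scatter of two such steps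

Still open, as far as these compounds go, is whether any change at these two places can separate compounds in this cell assay, for example a morpholin-4-yl or dimethylamino group in place of the ring amine, or a butyl or pentyl chain in place of the propyl chain. On the aromatic nitrogen, a methoxyphenyl, a pyridinyl or an unsubstituted phenyl group would test the same question at the other site.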